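The compounds below may be only part of what the source reports. "The series", "measured", "known", "first", "only" and "open" are said of these compounds alone.

Two compounds sharing the core and the same aryl ether arm have numbers in an assay on isolated protein for binding affinity to metabotropic glutamate receptor 2 (Homo sapiens); on this read-out higher numbers stand for an effect only at larger amounts of compound and lower numbers for an effect already at smaller amounts. Compound 1 `O=C1c2c(cc(OCc3cccc(CSc4ccncc4)c3)c(Cl)c2Cl)CC1C1CCCC1` gives 165 nM. Compound 2 `CC(C)C1Cc2cc(OCc3cccc(CSc4ccncc4)c3)c(Cl)c(Cl)c2C1=O` gives 839 nM, the highest of the two numbers; its nearest neighbour is compound 1, and the step of a 5.1-fold higher number from compound 1 to compound 2 (0.71 log units; beyond the scatter) separates them. Compound 3 `CCCC1Cc2cc(OCc3cccc(CSc4ccncc4)c3)c(Cl)c(Cl)c2C1=O` differs from compound 2 by propyl in place of isopropyl on a saturated ring carbon. The only measured step that bears on this carbon is a 5.1-fold higher number from compound 1 to compound 2 (0.71 log units; beyond the scatter), where a ring gave way to a branched chain; no measured pair sets a branched chain against an unbranched one of the same count, so the direction of the propyl change is not shown by the data. Since the one shift at this carbon was modest, a step of modest size at most is expected, most likely none beyond the scatter, as a 1.2-fold higher number from compound 2 to compound 3 (0.08 log units; within the scatter). Compound 3 is therefore estimated at 1000 nM in this assay, with a range from 400 nM to 2500 nM.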

Compound 3, half-maximal effective concentration: 186 nM
Compound 3: middle estimate off by 5.4-fold (0.73 log units), on the high side, and the stated range ends above it.
By their numbers in this assay, from the lowest: compounds 1 and 3 (each within the scatter of the next); then compound 2.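

Going from isopropyl to propyl on the saturated ring carbon, with the same heavy-atom count, gives a 4.5-fold lower number from compound 2 to compound 3 (0.65 log units; beyond the scatter) in this assay, so the arrangement of the chain, and not only its count, goes with the read-out at this position. Going from cyclopentyl to propyl gives a 1.1-fold higher number from compound 1 to compound 3 (0.05 log units; within the scatter), so loss of the ring alone does not go with a shift, and among the three groups only the isopropyl of compound 2 stands apart. Nothing measured here accounts for either step.

Going by these compounds, whether a longer chain such as butyl, or an amine on this carbon, stays within the scatter of compound 1 and compound 3 remains open. Also open is whether another branched chain, such as isobutyl or tert-butyl, follows isopropyl, as only one acyclic branched group is shown.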